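This account rests on a few compounds, and the source may have more. Where it says the series, first, only, none or still open, it means among the compounds named here.

In a functional assay on MGC-803 cells (Homo sapiens) for inhibition, read by sulforhodamine B assay (a higher number here means a weaker inhibitor, a lower number a stronger inhibitor), compound 2 `O=C1C=C(NC2CCCCC2)C(=O)c2c1nc1n2[C@H]2OC[C@@H](O)[C@H]2OC1` gives > 8000 nM, which is a limit of the assay. Compound 1 `Cc1ccc(NC2=CC(=O)c3c(nc4n3[C@H]3OC[C@@H](O)[C@H]3OC4)C2=O)cc1` gives 1550 nM and compound 3 `COc1ccccc1NC1=CC(=O)c2c(nc3n2[C@H]2OC[C@@H](O)[C@H]2OC3)C1=O` gives 1670 nM. Both carry aryl groups on an isomeric form of the core of compound 2. Among the compounds with values here, the only measured step, a 1.1-fold higher number from compound 1 to compound 3 (0.03 log units; within the scatter), stays within the scatter. Compound 4 `COc1ccccc1NC1=CC(=O)c2nc3n(c2C1=O)[C@H]1OC[C@@H](O)[C@H]1OC3` keeps the core of compound 2 and differs by 2-methoxyphenyl in place of cyclohexyl on an amine nitrogen. Within the data shown here, no measured step covers this change on that core, so the expectation rests loosely on compound 3 at 1670 nM. The expected step, an at least 3.2-fold lower number from compound 2 to compound 4 (0.50 log units; beyond the scatter), is estimated to run towards a stronger inhibitor in this assay. For compound 4 the expected value is 2500 nM, with an estimated range of 800 nM to 8000 nM.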

Compound 4, half-maximal inhibitory concentration: 1630 nM
Estimate against measurement, compound 4: 1.5-fold (0.19 log units) above; measured number inside the range.
By their numbers in this assay, from the lowest: compounds 1, 4 and 3 (each within the scatter of the next). At a limit, above all of these: compound 2.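

In this assay, the change from cyclohexylamino to (2-methoxyphenyl)amino gives an at least 4.9-fold lower number from compound 2 to compound 4 (0.69 log units; beyond the scatter). Within the data shown here, this is the first step beyond the scatter at this amine nitrogen, whereas the earlier step between two aryl groups stayed within it. The size of the step is open-ended, as compound 2 stands at a limit of the assay: the limit of > 8000 nM in this assay, at which 1 of the 4 values shown sits.

The compounds shown do not separate the aromatic ring from its methoxy group on this core. A plain phenyl or a benzyl group on the same amine nitrogen would bear on that question.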